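A few compounds are considered here, and "the series" means these few. Any claim that something is new, unique, unknown or untested is made for them only; others in the source may bear on it.

Measured so far:
compound 1 `Nc1cc(N)c2nc(-c3ccccc3)c(Oc3ccc(Cl)c(Cl)c3)nc2c1` — < 100000 nM
compound 2 `CCOC(=O)[C@H](CCC(=O)O)NC(=O)c1ccc(CNc2nc3cc(N)cc(N)c3nc2-c2ccccc2)cc1` — < 100000 nM
compound 3 `COc1cc(CNc2nc3cc(N)cc(N)c3nc2-c2ccccc2)cc(OC)c1OC` — 14800 nM

Compound 1 stands in a functional assay on A498 cells (Homo sapiens) for inhibition, read by sulforhodamine B assay, with a stated time of 48 h (a higher number here means a weaker inhibitor of growth, a lower number a stronger inhibitor of growth), only at a limit of the assay, < 100000 nM, not at a number. Compound 2 likewise reaches only a limit in this assay, < 100000 nM. Among the compounds with values here, compound 3 is the one compound of the three with a definite number in this assay, 14800 nM; it carries a benzylamino-type group where compound 1 carries an aryloxy group. Two of the three values shown sit at the same limit, as noted in the limit of < 100000 nM in this assay, at which 2 of the 3 values shown sit.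

Compound 4 `Nc1cc(N)c2nc(-c3ccccc3)c(NCc3ccc(F)cc3)nc2c1` is not yet measured in this assay. It differs from compound 1 in one place: (4-fluorobenzyl)amino in place of 3,4-dichlorophenoxy on an aromatic carbon. Since compound 1 is known only as a limit, the size of the step from compound 1 to compound 4 cannot be set from the data, and only an expectation can be given. Taking compound 3 as the nearest comparison, with its benzylamino group and its value of 14800 nM, compound 4 is expected to give a definite number of about 20000 nM in this assay, within 5000 nM to 80000 nM. The step implied from compound 1 to compound 4 is estimated as a step that the limit leaves unreadable from compound 1 to compound 4.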

Compound 4, concentration for total growth inhibition: 30900 nM
Beside the measured number, compound 4's estimate is 1.5-fold (0.19 log units) below it; measured number inside the range.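

The step between compound 1 and compound 4 cannot be read: in this assay, compound 1 stands only at a limit of the assay, < 100000 nM, not at a number. The compounds shown leave open how far (4-fluorobenzyl)amino and 3,4-dichlorophenoxy differ on the shared core in this assay.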